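The compounds below may be only part of what the source reports. "The series", "measured", "known", "first", "only" and "open" are said of these compounds alone.

Compound 1 `CCCCCC(=O)OCC1CN(C(=O)c2cc(OC)c(OC)c(OC)c2)CCN1C(=O)c1cc(OC)c(OC)c(OC)c1` gives 290 nM in a functional assay (Oryctolagus cuniculus) for inhibition of platelet-activating factor receptor (Cavia porcellus); a lower number here means a stronger inhibitor, a higher number a weaker inhibitor. Compound 2 `COc1cc(C(=O)N2CCN(C(=O)c3cc(OC)c(OC)c(OC)c3)C(COC(=O)CC(C)(C)C)C2)cc(OC)c1OC` gives 120 nM. Compound 3 `CCCCNC(=O)OCC1CN(C(=O)c2cc(OC)c(OC)c(OC)c2)CCN1C(=O)c1cc(OC)c(OC)c(OC)c1` gives 240 nM.

Compound 1 carries the highest of the three numbers: the step of a 1.2-fold lower number from compound 1 to compound 3 (0.08 log units; within the scatter) lies within the scatter, whereas a 2.4-fold lower number from compound 1 to compound 2 (0.38 log units; beyond the scatter) lies beyond it. Compound 4 `CCCC(C)NC(=O)OCC1CN(C(=O)c2cc(OC)c(OC)c(OC)c2)CCN1C(=O)c1cc(OC)c(OC)c(OC)c1` differs from compound 1 by (1-methylbutyl)amino in place of pentyl on a carbonyl carbon. The step that bears most directly on this change is a 1.2-fold lower number from compound 1 to compound 3 (0.08 log units; within the scatter), where butylamino replaced pentyl on the carbonyl carbon and the number barely moved; a 2.0-fold higher number from compound 2 to compound 3 (0.30 log units; within the scatter) likewise stayed within the scatter. No step beyond the scatter is therefore expected in this assay. Compound 4 is expected to give 230 nM, with a range from 110 nM to 480 nM. The expected step is a 1.3-fold lower number from compound 1 to compound 4 (0.10 log units; within the scatter).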

Compound 4, half-maximal inhibitory concentration: 100 nM
Compound 4: middle estimate off by 2.3-fold (0.36 log units), on the high side; measured number below the stated range.
By their numbers in this assay, from the lowest: compounds 4, 2, 3 and 1 (each within the scatter of the next, the first and the last beyond it).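

On the carbonyl carbon, (1-methylbutyl)amino in place of pentyl gives a 2.9-fold lower number from compound 1 to compound 4 (0.46 log units; beyond the scatter) in this assay, a step beyond the scatter, which butylamino in the same place did not give. Methyl in place of hydrogen on the chain carbon bound to the amide-type nitrogen gives a 2.4-fold lower number from compound 3 to compound 4 (0.38 log units; beyond the scatter), while a 1.2-fold lower number from compound 2 to compound 4 (0.08 log units; within the scatter) stays within the scatter, so (1-methylbutyl)amino and neopentyl cannot be told apart here. Nothing available explains these steps. On these data alone, whether tert-butylamino or cyclopentylamino on this carbonyl carbon would match compound 4 remains open. So does whether the amide hydrogen is needed, which dimethylamino could test.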